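This account rests on a few compounds, and the source may have more. Where it says the series, first, only, none or still open, it means among the compounds named here.

Of the compounds shown here, three have been measured in a functional assay on DLD-1 cells (Homo sapiens) for antiproliferative activity, read by CellTiter-Glo, with a stated time of 72 h; a higher number here means a weaker inhibitor, a lower number a stronger inhibitor. Compound 1, `Cc1cc(C)c(S(=O)(=O)N2CCC(N3CCC(c4ccccc4)CC3)CC2)c(C)c1`, gives 865 nM. Compound 2, `CC1CCN(C2CCN(S(=O)(=O)c3cccnc3)CC2)CC1`, gives 2400 nM, the higher of the two numbers, with compound 1 sitting lower by a margin beyond the usual scatter. Compound 3, `Cc1cc(C)c(S(=O)(=O)N2CCC(c3ccccc3)CC2)c(C)c1`, reaches only the limit of the assay, > 5000 nM, so no number is known for it; this is the case described by the limit of > 5000 nM in this assay, at which 1 of the 3 values shown sits.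

Compound 4, `CC1CCN(C2CCN(S(=O)(=O)c3ccc(Cl)nc3)CC2)CC1`, has not yet been measured in this assay . It differs from compound 2 in one place: chloro in place of hydrogen on an aromatic carbon. Among the measured compounds shown here, no pair of measured compounds shows what such a change does here, and neither compound 1 nor compound 3 shares this change with compound 2, so no step size can be read from the data.

For this reason the expectation for compound 4 is a step from compound 2 of a 1.2-fold lower number from compound 2 to compound 4 (0.08 log units; within the scatter), meaning no change beyond the scatter in either direction. Compound 4 is thus estimated to give 2000 nM in this assay , with a range from 700 nM to 6000 nM.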

Compound 4, half-maximal inhibitory concentration: 3700 nM
Estimate against measurement, compound 4: 1.9-fold (0.27 log units) below, within the range that was stated.
By their numbers in this assay, from the lowest: compound 1; then compounds 2 and 4 (each within the scatter of the next). At a limit, above all of these: compound 3.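

Going from pyridin-3-yl to 6-chloropyridin-3-yl gives a 1.5-fold higher number from compound 2 to compound 4 (0.19 log units; within the scatter) in this assay. Among the compounds shown here, this is the first reading for this position: on an aromatic carbon next to the ring nitrogen, a chlorine atom can replace hydrogen with no change that stands out from the ordinary spread of repeated measurements. Compound 4 also gives a real number and does not join the one compound that sits at a limit of the assay: the limit of > 5000 nM in this assay, at which 1 of the 4 values shown sits.

From the compounds shown here alone, whether a different group at this carbon, such as an amine, a methoxy group or a nitrile, would shift the number beyond the scatter remains open. So does the question of whether chloro would behave the same way on another carbon of this ring.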